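Adding a Fluorine to the Benzoyl Arm of Compound 2

The source may report more compounds than this note shows. Statements on the series, on what has been measured and on what is new or still open speak of the compounds shown alone.

Of the compounds shown here, two sharing one core have been tested in a functional assay on HepG2 cells (Homo sapiens) for inhibition, read by MTT assay, with a stated time of 48 h; a lower number here means a stronger inhibitor, a higher number a weaker inhibitor. Compound 1 `COc1ccc(CSc2nnc(-c3cc(OC)c(OC)c(OC)c3)n2-c2ccc(OC)cc2)cc1` gives 41100 nM in this assay. For the measured compounds named here, compound 2 `COc1ccc(-n2c(SCC(=O)c3ccccc3)nnc2-c2cc(OC)c(OC)c(OC)c2)cc1` gives 16200 nM in this assay, the lower of the two numbers, and the only measured step is a 2.5-fold lower number from compound 1 to compound 2 (0.40 log units; beyond the scatter), a change on the saturated chain carbon bound to a sulfur.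

Compound 3 `COc1ccc(-n2c(SCC(=O)c3ccc(F)cc3)nnc2-c2cc(OC)c(OC)c(OC)c2)cc1` has not yet been measured. Going by the values given here, the difference from compound 2 is fluoro in place of hydrogen on an aromatic carbon, and no measured step touches this ring or this kind of change, so the one step on record does not bear on it. A single fluorine entering on an aromatic carbon, with no donor or acceptor added, is the sort of change that in the absence of any guiding step is expected to stay within the usual spread of repeated measurements. Compound 3 is therefore expected to give about 13000 nM in this assay, somewhere between 6000 nM and 35000 nM, because compound 2 gives 16200 nM and the expected step is a 1.2-fold lower number from compound 2 to compound 3 (0.10 log units; within the scatter).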

Compound 3, half-maximal inhibitory concentration: 10700 nM
Estimate against measurement, compound 3: 1.2-fold (0.08 log units) above, within the range that was stated.
By their numbers in this assay, from the lowest: compounds 3 and 2 (each within the scatter of the next); then compound 1.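

In this assay, fluoro in place of hydrogen on the benzoyl ring, para to a large group, comes with a 1.5-fold lower number from compound 2 to compound 3 (0.18 log units; within the scatter), so the two compounds cannot be told apart at this position, and a single fluorine here gives no clear gain or loss. The wider comparison, (4-fluorophenyl)carbonyl in place of 4-methoxyphenyl on the saturated chain carbon bound to a sulfur, is a 3.8-fold lower number from compound 1 to compound 3 (0.58 log units; beyond the scatter), so the advantage of a carbonyl-bearing arm over the 4-methoxyphenyl arm now rests on two compounds rather than one. No measurement is available to explain why either of these numbers takes the value it does.

The compounds shown leave open whether a chlorine, a methoxy group or an amine on this same ring carbon would give a number that stands clear of the scatter, and whether fluoro on another carbon of the ring would read like compound 3. They also leave open how a longer chain on the sulfur, or a carboxylic acid at the end of that chain, would read in this assay.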